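Piperidinyl for diethylamino on the tert-butyl core

A few compounds are considered here, and "the series" means these few. Any claim that something is new, unique, unknown or untested is made for them only; others in the source may bear on it.

Compound 1 `CCN(CC)CCNc1n[n+]([O-])c2ccc(Cl)cc2[n+]1[O-]` gives 300 nM in a functional assay on HT-29 cells (Homo sapiens) for cytotoxicity, with a stated time of 4 h; a higher number here means a weaker inhibitor, a lower number a stronger inhibitor. Compound 2 `[O-][n+]1nc(NCCN2CCCCC2)[n+]([O-])c2cc(Cl)ccc21` carries piperidin-1-yl in place of diethylamino on a saturated chain carbon, two bonds along the chain from a nitrogen on an aromatic ring and gives 400 nM; the step of a 1.3-fold higher number from compound 1 to compound 2 (0.12 log units; within the scatter). Compound 3 `CCN(CC)CCNc1n[n+]([O-])c2ccc(C(C)(C)C)cc2[n+]1[O-]` differs from compound 1 in the core, (tert-butyl in place of chloro on an aromatic carbon); in this assay compound 3 gives 4300 nM; the step of a 14-fold higher number from compound 1 to compound 3 (1.16 log units; beyond the scatter). Compound 4 `CC(C)(C)c1ccc2c(c1)[n+]([O-])c(NCCN1CCCCC1)n[n+]2[O-]` is unmeasured; it carries piperidin-1-yl in place of diethylamino on a saturated chain carbon, two bonds along the chain from a nitrogen on an aromatic ring on the core of compound 3, the same change as from compound 1 to compound 2, at the same place. Since that change stayed within the scatter between compound 1 and compound 2 and the core change is large, compound 4 is expected to stay close to compound 3, with an expected step of a 1.3-fold higher number from compound 3 to compound 4 (0.11 log units; within the scatter). The estimate for compound 4 is 5500 nM, expected between 2500 nM and 12000 nM.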

Compound 4, half-maximal inhibitory concentration: 4000 nM
Compound 4: the middle estimate sits 1.4-fold (0.14 log units) above what was measured, and the stated range covers the measured number.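

In this assay piperidin-1-yl in place of diethylamino on the core of compound 3 gives a 1.1-fold lower number from compound 3 to compound 4 (0.03 log units; within the scatter) and matches the step on the core of compound 1: the same change on two cores in this assay, a 1.3-fold higher number (0.12 log units; within the scatter) from compound 1 to compound 2 and a 1.1-fold lower number (0.03 log units; within the scatter) from compound 3 to compound 4, 1.4-fold (0.16 log units) apart, within the scatter of two such steps
The tert-butyl for chloro change also carries over from the diethylamino compounds to the piperidin-1-yl compounds, with a 10-fold higher number from compound 2 to compound 4 (1.00 log units; beyond the scatter) on the latter pair: the same change on two cores in this assay, a 14-fold higher number (1.16 log units; beyond the scatter) from compound 1 to compound 3 and a 10-fold higher number (1.00 log units; beyond the scatter) from compound 2 to compound 4, 1.4-fold (0.16 log units) apart, within the scatter of two such steps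
For the compounds shown here, the two changes therefore behave independently across these four compounds, but this rests on only two cores and one amine exchange, and it does not show why either step has its size.

Still open, on these data alone, is whether this holds for a morpholine or a pyrrolidine in place of piperidin-1-yl, or for a longer chain carrying the amine. A methoxy or trifluoromethyl group in place of chloro is equally untested among the compounds shown.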